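Compound 4: a para-iodophenyl variant awaiting measurement

A few compounds are considered here, and "the series" means these few. Any claim that something is new, unique, unknown or untested is made for them only; others in the source may bear on it.

Measured so far:
- compound 1, `O=c1[nH]/c(=N\OCCCCc2ccccc2)ccn1[C@@H]1O[C@H](COP(=O)(O)OP(=O)(O)OP(=O)(O)O)[C@@H](O)[C@H]1O`, 54 nM
- compound 2, `O=c1[nH]/c(=N\OCCCc2cccc(F)c2)ccn1[C@@H]1O[C@H](COP(=O)(O)OP(=O)(O)OP(=O)(O)O)[C@@H](O)[C@H]1O`, 100 nM
- compound 3, `O=c1[nH]/c(=N\OCCCc2cccc(I)c2)ccn1[C@@H]1O[C@H](COP(=O)(O)OP(=O)(O)OP(=O)(O)O)[C@@H](O)[C@H]1O`, 114 nM

In a functional assay on 1321-N1 cells for agonist activity at P2Y purinoceptor 4 (Homo sapiens), read by scintillation counting and inositol phosphate accumulation (a higher number here means that more compound is needed for the effect, a lower number that less compound is needed), compound 2 stands second highest of the three numbers; its nearest neighbour is compound 3 (a 1.1-fold higher number from compound 2 to compound 3 (0.06 log units; within the scatter)) and its furthest is compound 1 (a 1.9-fold higher number from compound 1 to compound 2 (0.27 log units; within the scatter)). Compound 4, `O=c1[nH]/c(=N\OCCCc2ccc(I)cc2)ccn1[C@@H]1O[C@H](COP(=O)(O)OP(=O)(O)OP(=O)(O)O)[C@@H](O)[C@H]1O`, is the next step: 4-iodophenyl in place of 3-fluorophenyl on a saturated chain carbon, three bonds along the chain from an oxygen. Within the data shown here, of the measured steps, only a 1.1-fold higher number from compound 2 to compound 3 (0.06 log units; within the scatter) bears on the halogen exchange, and it stayed within the scatter; no measured step shows the move of the halogen to another ring position. Compound 4 is therefore expected to sit close to compound 2 in this assay, with an expected step of a 1.1-fold higher number from compound 2 to compound 4 (0.04 log units; within the scatter). The estimate for compound 4 is 110 nM, with a range of 50 nM to 250 nM.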

Compound 4, half-maximal effective concentration: 91 nM
Compound 4: middle estimate off by 1.2-fold (0.08 log units), on the high side, and the stated range covers the measured number.
By their numbers in this assay, from the lowest: compounds 1, 4, 2 and 3 (each within the scatter of the next, the first and the last beyond it).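

In this assay, the shift of iodine from the 3-iodophenyl of compound 3 to the 4-iodophenyl of compound 4 gives a 1.3-fold lower number from compound 3 to compound 4 (0.10 log units; within the scatter) and so stays inside the scatter. Replacing 3-fluorophenyl gives a 1.1-fold lower number from compound 2 to compound 4 (0.04 log units; within the scatter) and replacing benzyl gives a 1.7-fold higher number from compound 1 to compound 4 (0.23 log units; within the scatter) so that compound 4 is not separated from any of the three earlier compounds. Nothing available explains why these numbers lie so close.

The compounds shown leave open whether an amine or a carboxylic acid on the ring would stay this close. They also leave open what a longer chain carrying 4-iodophenyl would give.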